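The source may hold more compounds than are shown below. What is called first, only, known or untested is meant among the compounds shown, and "the series" means these compounds.

In an ADME assay on microsomes from liver (Homo sapiens) for metabolic stability, with a stated time of 30 min, tested at 1 uM (a lower number here means that less of the compound is left, a higher number that more of the compound is left), compound 1 (`Cc1ccc(Nc2ncc3c(n2)N(C)C(=O)N(c2cc(NC(=O)c4ccc(CN5CCC(N(C)C)C5)c(C(F)(F)F)c4)ccc2C)C3)cn1`) gives 57.5% and compound 2 (`Cc1ccc(NC(=O)c2cccc(C(F)(F)F)c2)cc1N1Cc2cnc(Nc3cnn(C)c3)nc2N(C)C1=O`) gives 78.8% as the higher of the two numbers, with a gap beyond the usual scatter. Compound 3 (`Cc1cc(Nc2ncc3c(n2)N(C)C(=O)N(c2cc(NC(=O)c4cccc(C(F)(F)F)c4)ccc2C)C3)n(C)n1`) has not yet been measured. It differs from compound 2 in one place, on a nitrogen on an aromatic ring, and the change is 1,3-dimethyl-1H-pyrazol-5-yl in place of 1-methyl-1H-pyrazol-4-yl on a nitrogen on an aromatic ring in which 1,3-dimethyl-1H-pyrazol-5-yl takes the place of 1-methyl-1H-pyrazol-4-yl. Going by the values given here, no measured pair shows the effect of this swap, so the forecast is loose. Among the compounds with values here, the starting point is compound 2 at 78.8% and this is the higher of only two numbers. A small fall is therefore expected, with a number 6.8 percentage points lower from compound 2 to compound 3 (within the scatter) as the estimated step, and this would stay within the scatter. For compound 3 the expected value is 72% with an estimated range from 52% to 88% as the likely span.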

Compound 3, percent of the compound remaining: 69.2%
Compound 3: middle estimate off by 2.8 percentage points, on the high side, within the range that was stated.
By their numbers in this assay, from the lowest: compound 1; then compounds 3 and 2 (each within the scatter of the next).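

In this assay, going by these compounds alone, this is the first pair of compounds that differ in only one place, the group on a nitrogen on an aromatic ring, and it gives a number 9.6 percentage points lower from compound 2 to compound 3 (within the scatter). Replacing 1-methyl-1H-pyrazol-4-yl with 1,3-dimethyl-1H-pyrazol-5-yl therefore has no effect here that can be told apart from the usual variation between repeated measurements, even though the ring's attachment point changes and a methyl group is added. No measurement bears on how this swap acts on the compound's stability.

The swap makes both changes at once, so 1-methyl-1H-pyrazol-5-yl would be needed to show each one's separate contribution. Going by these compounds, it also remains open whether this position would accept a group other than a methylated pyrazole, such as a morpholine ring or an open-chain amine.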